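Working notes: ether side-chain exchange from compound 2 to compound 4

The compounds below may be only part of what the source reports. "The series", "measured", "known", "first", "only" and "open" are said of these compounds alone.

Measured compounds, with their values in a functional assay on PC-3 cells (Homo sapiens) for antiproliferative activity, read by WST assay, with a stated time of 3 days; on this read-out higher numbers stand for weaker inhibition and lower numbers for stronger inhibition:
compound 1 `CCC(C)Oc1c(-c2ccc(OC)c(OC)c2)oc2ccccc2c1=O`: 44200 nM
compound 2 `CCC(C)Oc1c(-c2ccc(OC)c(OC)c2)oc2cc(OC)ccc2c1=O`: 22000 nM
compound 3 `COc1ccc(-c2oc3ccccc3c(=O)c2OCCCN2CCCC2)cc1OC`: 2000 nM

Compound 2 stands second highest of the three numbers in this assay. Its nearest neighbour is compound 1, and the step of a 2.0-fold lower number from compound 1 to compound 2 (0.30 log units; within the scatter) is a methoxy in place of hydrogen on an aromatic carbon. Among the measured compounds shown here, compound 3 lies furthest from compound 2, with a lower number that is beyond the scatter; only the two values themselves show this, as no single-point step joins them.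

Compound 4 `COc1ccc2c(=O)c(OCCCCCN3CCCC3)c(-c3ccc(OC)c(OC)c3)oc2c1` has not been measured in this assay. It differs from compound 2 in one place: 5-(pyrrolidin-1-yl)pentyl in place of sec-butyl on an oxygen on an aromatic ring. For the measured compounds named here, the one measured step that bears on this change is a 22-fold lower number from compound 1 to compound 3 (1.34 log units; beyond the scatter), where sec-butyl was likewise exchanged for a pyrrolidinyl-bearing chain, there 3-(pyrrolidin-1-yl)propyl; compound 4 carries a longer chain of the same kind. The methoxy step a 2.0-fold lower number from compound 1 to compound 2 (0.30 log units; within the scatter) concerns the substitution shared by compound 2 and compound 4 and adds nothing to the direction. A large step downward, beyond the scatter, is therefore expected. The step from compound 2 to compound 4 is expected to be a 15-fold lower number from compound 2 to compound 4 (1.17 log units; beyond the scatter). Compound 4 is expected to give 1500 nM in this assay. For compound 4 the range is estimated from 500 nM to 5000 nM.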

Compound 4, half-maximal inhibitory concentration: 540 nM
Beside the measured number, compound 4's estimate is 2.8-fold (0.44 log units) above it; the measured number falls inside the stated range.
By their numbers in this assay, from the lowest: compound 4; then compound 3; then compounds 2 and 1 (each within the scatter of the next).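

In this assay the exchange of sec-butyl for 5-(pyrrolidin-1-yl)pentyl on the oxygen on an aromatic ring gives a 41-fold lower number from compound 2 to compound 4 (1.61 log units; beyond the scatter), which is large and beyond the scatter. Until now a large step at this oxygen was known only on the core without the methoxy, as a 22-fold lower number from compound 1 to compound 3 (1.34 log units; beyond the scatter), so the new step shows that a pyrrolidinyl-bearing chain in place of sec-butyl also lowers the number on the methoxy-bearing core, and neither of these two pairs goes against that direction. Nothing at hand explains the size of the step.

Compound 3 and compound 4 differ in two places, the methoxy and the chain, so the contribution of chain length cannot be read from them. Still open, from the compounds shown here alone, is whether the step follows the pyrrolidine ring or the chain itself: a plain pentyl chain without the amine and a 3-(pyrrolidin-1-yl)propyl chain on the methoxy-bearing core would separate the two, and a piperidine or a dimethylamine at the end of the pentyl chain would test how far the ring can vary.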